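Replacing an ethoxy group with a (4-iodophenyl)amino group

A few compounds are considered here, and "the series" means these few. Any claim that something is new, unique, unknown or untested is made for them only; others in the source may bear on it.

Compound 1 `CCOC1=C(C(=O)c2ccccc2)C(c2ccc(Br)cc2)N(CCCn2ccnc2)C1=O` was tested in a functional assay on NCI-H1299 cells (Homo sapiens) for antiproliferative activity, read by MTT assay, with a stated time of 72 h (a lower number here means a stronger inhibitor, a higher number a weaker inhibitor), where compound 1 gives 28900 nM. Among the three compounds measured this is the highest number: compound 2 `CCCCCOC1=C(C(=O)c2ccccc2)C(c2ccc(Br)cc2)N(CCCn2ccnc2)C1=O` gives 10300 nM in this assay, and compound 3 `O=C(C1=C(Nc2ccc(F)cc2)C(=O)N(CCCn2ccnc2)C1c1ccc(Br)cc1)c1ccccc1` gives 25400 nM. The two single-point steps from compound 1 are a 2.8-fold lower number from compound 1 to compound 2 (0.45 log units; beyond the scatter) and a 1.1-fold lower number from compound 1 to compound 3 (0.06 log units; within the scatter); between the other pair the step is a 2.5-fold higher number from compound 2 to compound 3 (0.39 log units; beyond the scatter).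

Compound 4 `O=C(C1=C(Nc2ccc(I)cc2)C(=O)N(CCCn2ccnc2)C1c1ccc(Br)cc1)c1ccccc1` has not yet been measured in this assay. It differs from compound 1 in one place: (4-iodophenyl)amino in place of ethoxy on a double-bonded ring carbon. The measured step that bears on this change is the one in which a (4-fluorophenyl)amino group replaced ethoxy, a 1.1-fold lower number from compound 1 to compound 3 (0.06 log units; within the scatter), which lies within the scatter. Among the measured compounds shown here, the entering group of compound 4 differs from that of compound 3 only in the halogen, iodine in place of fluorine, and no measured pair shows what that exchange does. The step is therefore expected to be a 1.2-fold lower number from compound 1 to compound 4 (0.08 log units; within the scatter), not beyond the scatter in either direction. Compound 4 is expected to give 24000 nM in this assay, within a range from 9000 nM to 60000 nM.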

Compound 4, half-maximal inhibitory concentration: 19400 nM
Beside the measured number, compound 4's estimate is 1.2-fold (0.09 log units) above it; the measured number falls inside the stated range.
By their numbers in this assay, from the lowest: compounds 2, 4, 3 and 1 (each within the scatter of the next, the first and the last beyond it).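

In this assay the double-bonded ring carbon takes (4-iodophenyl)amino in place of ethoxy with a 1.5-fold lower number from compound 1 to compound 4 (0.17 log units; within the scatter) as the whole step, so a second halogen-bearing phenylamino group also leaves the number close to that of the ethoxy compound. Among the compounds shown here, the halogen exchange that no earlier pair covered gives a 1.3-fold lower number from compound 3 to compound 4 (0.12 log units; within the scatter) and leaves iodo and fluoro on the aromatic carbon without a readable difference. The step of a 2.5-fold higher number from compound 2 to compound 3 (0.39 log units; beyond the scatter) had set the pentyloxy compound apart from the fluorinated one, but a 1.9-fold higher number from compound 2 to compound 4 (0.27 log units; within the scatter) does not do so for the iodinated one, so pentyloxy no longer stands clear of every phenylamino group at this carbon.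

Nothing at hand gives a reason for any of these steps. Still open, going by these compounds, is whether an unsubstituted phenylamino group, a methoxy on that ring, or a pentylamino chain at this carbon would move the number beyond the scatter.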